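Swapping the Amide Side Group on a Shared Core

This account rests on a few compounds, and the source may have more. Where it says the series, first, only, none or still open, it means among the compounds named here.

Three compounds share one core and differ only in the group on a ring amine nitrogen. In an assay on isolated protein for binding affinity to histamine H2 receptor (Homo sapiens) (a lower number here means a stronger inhibitor, a higher number a weaker inhibitor), compound 1 `CCCCCC(=O)c1ccc(OCCCN2CCNCC2)cc1` gives 14500 nM. Compound 2 `CCCCCC(=O)c1ccc(OCCCN2CCN(C(=O)c3c[nH]cn3)CC2)cc1` gives 19500 nM, and compound 3 `CCCCCC(=O)c1ccc(OCCCN2CCN(C(=O)CSCC)CC2)cc1` gives 22900 nM. Compound 3 thus sits among numbers that all lie close together: the steps of a 1.3-fold higher number from compound 1 to compound 2 (0.13 log units; within the scatter), a 1.6-fold higher number from compound 1 to compound 3 (0.20 log units; within the scatter) and a 1.2-fold higher number from compound 2 to compound 3 (0.07 log units; within the scatter) each stay within the scatter. Compound 4 `CCCCCC(=O)c1ccc(OCCCN2CCN(C(=O)C(C)(C)O)CC2)cc1` differs from compound 3 by 1-hydroxy-1-methylethyl in place of (ethylsulfanyl)methyl on a carbonyl carbon. Since the earlier changes on this carbonyl barely moved the number, no step beyond the scatter is expected here either. Compound 4 is therefore estimated at 20000 nM, with a range from 8000 nM to 50000 nM. That estimate means an expected step of a 1.1-fold lower number from compound 3 to compound 4 (0.06 log units; within the scatter).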

Compound 4, inhibition constant: 24500 nM
For compound 4 the middle estimate is 1.2-fold (0.09 log units) below the measured one; low and high end bracket the measured number.
By their numbers in this assay, from the lowest: compounds 1, 2, 3 and 4 (each within the scatter of the next).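

The incoming 1-hydroxy-1-methylethyl carries a hydrogen-bond donor where (ethylsulfanyl)methyl carries none, yet a 1.1-fold higher number from compound 3 to compound 4 (0.03 log units; within the scatter) lies within the scatter in this assay. The comparison with 1H-imidazol-4-yl gives a 1.3-fold higher number from compound 2 to compound 4 (0.10 log units; within the scatter) and the comparison with hydrogen on the amine nitrogen gives a 1.7-fold higher number from compound 1 to compound 4 (0.23 log units; within the scatter) and both also lie within the scatter, so adding this donor-bearing group to the series leaves all four compounds indistinguishable. Nothing available explains this flat result.

From the compounds shown here alone, whether an amine or a carboxylic acid on this carbonyl carbon would give a step beyond the scatter stays open. So does whether a change elsewhere on the shared core would do so.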